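From 3-methoxyphenyl to cyclopropyl at the mouse receptor

The source may hold more compounds than are shown below. What is called first, only, known or untested is meant among the compounds shown, and "the series" means these compounds.

Compound 1 `CCCCc1cnc(C(C)Cc2ccc(-c3ccccc3C(=O)O)cc2)[nH]1`: 184 nM
Compound 2 `COc1cccc(Cc2cnc(CCc3ccc(-c4ccccc4C(=O)O)cc3)[nH]2)c1`: 79 nM

In an in vitro functional assay on cells for agonist activity at Bombesin receptor subtype-3 (Mus musculus), read by luminescence and calcium flux (on this read-out higher numbers stand for an effect only at larger amounts of compound and lower numbers for an effect already at smaller amounts), compound 2 holds the lower of the two numbers, and compound 1 stands a margin beyond the usual scatter above it. Compound 3 `O=C(O)c1ccccc1-c1ccc(CCc2ncc(CC3CC3)[nH]2)cc1` awaits measurement in this assay. It differs from compound 2 by cyclopropyl in place of 3-methoxyphenyl on a saturated chain carbon bound to an aromatic carbon. Among the compounds with values here, no measured pair shows this change, so the expectation rests on the two values alone. A step toward a higher number is expected from compound 2 to compound 3, a 3.8-fold higher number from compound 2 to compound 3 (0.58 log units; beyond the scatter), because compound 1 gives 184 nM without an aromatic ring on that chain. Compound 3 is estimated at 300 nM, between 100 nM and 1000 nM.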

Compound 3, half-maximal effective concentration: 72 nM
Compound 3: the middle estimate sits 4.2-fold (0.62 log units) above what was measured, and the stated range ends above it.
By their numbers in this assay, from the lowest: compounds 3 and 2 (each within the scatter of the next); then compound 1.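

In this assay, cyclopropyl in place of 3-methoxyphenyl on a saturated chain carbon bound to an aromatic carbon gives a 1.1-fold lower number from compound 2 to compound 3 (0.04 log units; within the scatter). This position therefore accepts either a three-membered non-aromatic ring or a six-membered aromatic ring with no change beyond the scatter, so neither the aromatic ring nor the oxygen of 3-methoxyphenyl is needed to hold this level here. No supporting data explain this result. Still open, on these data alone, is whether an amine or a longer chain at this position would hold the same level, and whether unsubstituted phenyl would match 3-methoxyphenyl.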